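Swapping a methoxyphenyl for a dichlorophenyl on an inactive parent

The source may report more compounds than this note shows. Statements on the series, on what has been measured and on what is new or still open speak of the compounds shown alone.

Measured compounds:
- compound 1, `C=CCn1c(=O)/c(=C\c2cccc(Cl)c2)[nH]c(=O)/c1=C\c1ccccc1OC`: 4600 nM
- compound 2, `COc1ccccc1/C=c1/[nH]c(=O)/c(=C\c2ccccc2OC)n(C)c1=O`: "not active" (no number reported)
- compound 3, `C=CCn1c(=O)/c(=C\c2ccccc2OC)[nH]c(=O)/c1=C\c1ccccc1OC`: 13400 nM

All three share one core, each carrying two aryl groups on double-bonded chain carbons. In a functional assay on BGC-823 cells (Homo sapiens) for cytotoxicity, read by CCK-8 assay, with a stated time of 72 h (on this read-out lower numbers stand for stronger inhibition and higher numbers for weaker inhibition), compound 1 gives 4600 nM, while compound 3 gives 13400 nM; the change between them is a 2.9-fold higher number from compound 1 to compound 3 (0.46 log units; beyond the scatter). Compound 2 stands apart: in this assay compound 2 is reported as "not active" (no number reported), so no number is available for it, and nothing can be said about how far it lies from compound 3.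

Compound 4, `COc1ccccc1/C=c1\c(=O)[nH]/c(=C/c2cccc(Cl)c2Cl)c(=O)n1C`, differs from compound 2 in one place: 2,3-dichlorophenyl in place of 2-methoxyphenyl on a double-bonded chain carbon bound to an aromatic carbon. For the measured compounds named here, the only measured step that bears on this is the change from compound 1 to compound 3, where a methoxyphenyl replacing a chlorophenyl raised the number; the present change runs the other way, from methoxy to chlorines, so a lower number than compound 2 would be expected, by a modest amount. From the compounds shown here alone, because compound 2 is "not active" (no number reported), the starting point is unknown, and the number expected for compound 4 is correspondingly uncertain. The estimate for compound 4 in this assay is 20000 nM, within a range of 4000 nM to 100000 nM.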

Compound 4, half-maximal inhibitory concentration: 300 nM
For compound 4 the middle estimate is 67-fold (1.82 log units) above the measured one; the measured number lies below the stated range.
By their numbers in this assay, from the lowest: compound 4; then compound 1; then compound 3.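

No new step can be read from compound 4, since compound 2, which differs from it in one place, is reported as "not active" with no number. The compounds shown leave open how far the 2,3-dichlorophenyl alone accounts for the value of compound 4, 300 nM. No measurement shown here offers an explanation for this result.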